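Working notes: amino in place of nitro

The source may hold more compounds than are shown below. What is called first, only, known or untested is meant among the compounds shown, and "the series" means these compounds.

Compound 1 `COc1cc(OC)c(/C=C/S(=O)(=O)Cc2ccc(F)c(N)c2)c(OC)c1` - 2500 nM
Compound 2 `COc1cc(OC)c(/C=C/S(=O)(=O)Cc2ccc(OC)cc2[N+](=O)[O-])c(OC)c1` - 20000 nM

In a functional assay on K562 cells (Homo sapiens) for cytotoxicity, read by trypan blue exclusion, with a stated time of 96 h (on this read-out lower numbers stand for stronger inhibition and higher numbers for weaker inhibition), compound 2 stands highest of the two at 20000 nM and compound 1 lies lower, a gap beyond the scatter. Compound 3 `COc1ccc(CS(=O)(=O)/C=C/c2c(OC)cc(OC)cc2OC)c(N)c1` carries amino in place of nitro on an aromatic carbon. Among the compounds with values here, no measured pair isolates this change. Within the data shown here, compound 1, which also bears an amino group, gives 2500 nM in this assay and this is the only guide available. A move to a lower number, beyond the scatter, is expected (a 10-fold lower number from compound 2 to compound 3 (1.00 log units; beyond the scatter)). Compound 3 is estimated at 2000 nM with an expected range from 250 nM to 12000 nM in this series.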

Compound 3, half-maximal inhibitory concentration: 25 nM
For compound 3 the middle estimate is 80-fold (1.90 log units) above the measured one, outside the stated range (below it).
By their numbers in this assay, from the lowest: compound 3; then compound 1; then compound 2.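

In this assay, within the data shown here, the aromatic carbon ortho to a large group and meta to a methoxy group proves highly sensitive: amino in place of nitro gives an 800-fold lower number from compound 2 to compound 3 (2.90 log units; beyond the scatter) and isolates this change for the first time. An amino group alone does not set the level, since 2-amino-4-methoxyphenyl in place of 3-amino-4-fluorophenyl gives a 100-fold lower number from compound 1 to compound 3 (2.00 log units; beyond the scatter) on the same saturated chain carbon. Nothing available accounts for either step. Open, from the compounds shown here alone, is how a hydroxyl or an acetamide on that aromatic carbon would compare in this assay with the amino group of compound 3.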